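Antiproliferative series: adding a hydroxy to the dimethylamino amide

The source may report more compounds than this note shows. Statements on the series, on what has been measured and on what is new or still open speak of the compounds shown alone.

- compound 1 `C=C(c1cc(OC)c(OC)c(OC)c1)c1ccc(OC)cc1NC(=O)CO`: 40 nM
- compound 2 `C=C(c1cc(OC)c(OC)c(OC)c1)c1ccc(OC)cc1NC(=O)CN`: 60 nM
- compound 3 `C=C(c1cc(OC)c(OC)c(OC)c1)c1ccc(OC)cc1NC(=O)CN(C)C`: 340 nM

In a functional assay on HCT-8 cells (Homo sapiens) for antiproliferative activity, read by MTT assay, with a stated time of 48 h (on this read-out higher numbers stand for weaker inhibition and lower numbers for stronger inhibition), compound 3 gives the highest number of the three, at 340 nM, and is the weakest of this small set. The next change leads to compound 4 `C=C(c1cc(OC)c(OC)c(OC)c1)c1ccc(OC)c(O)c1NC(=O)CN(C)C`: hydroxy in place of hydrogen on an aromatic carbon. The hydroxy stands in place of hydrogen on an aromatic carbon, ortho to the (((dimethylamino)methyl)carbonyl)amino group and ortho to a methoxy group.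

Within the data shown here, no measured step touches the aromatic ring. All three lie on the saturated chain carbon bound to the carbonyl carbon: a 1.5-fold higher number from compound 1 to compound 2 (0.18 log units; within the scatter), an 8.5-fold higher number from compound 1 to compound 3 (0.93 log units; beyond the scatter) and a 5.7-fold higher number from compound 2 to compound 3 (0.75 log units; beyond the scatter). They give only a rough scale for a single change, not a direction for this one, so the expected range is wide. No step beyond the scatter is expected in this assay, and the estimated step is a 1.7-fold lower number from compound 3 to compound 4 (0.23 log units; within the scatter), a slightly lower number. For compound 4 the estimated value is 200 nM, with an expected range of 50 nM to 800 nM.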

Compound 4, half-maximal inhibitory concentration: 110 nM
Compound 4: middle estimate off by 1.8-fold (0.26 log units), on the high side; the range from low to high includes it.
By their numbers in this assay, from the lowest: compounds 1, 2 and 4 (each within the scatter of the next, the first and the last beyond it); then compound 3.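

In this assay, the aromatic carbon ortho to the (((dimethylamino)methyl)carbonyl)amino group and ortho to a methoxy group responds to substitution: hydroxy in place of hydrogen there gives a 3.1-fold lower number from compound 3 to compound 4 (0.49 log units; beyond the scatter), a change towards stronger inhibition. Among these compounds, this is the first measured step on the aromatic ring, as all earlier steps lay on the saturated chain carbon bound to the carbonyl carbon, and it gives this ring position a direction of its own. No supporting measurement accounts for the step.

Going by these compounds, whether the same hydroxy lowers the number on the chains of compound 1 and compound 2 stays open. Also open, on these data alone, is whether a fluorine, a methoxy or an amine on this aromatic carbon would give a step like that of the hydroxy.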